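Cyclopropyl in place of trifluoromethoxy: cell toxicity of compound 4

A few compounds are considered here, and "the series" means these few. Any claim that something is new, unique, unknown or untested is made for them only; others in the source may bear on it.

Compound 1 is `COc1cccc(NC(=O)c2nnn(Cc3ccc([S+](C)[O-])cc3)c2N)c1`. In a toxicity assay on Vero cells (Chlorocebus sabaeus) for inhibition (a higher number here means that more compound is needed for the effect, a lower number that less compound is needed), compound 1 gives > 50100 nM, which is a limit of the assay and not a number.
Compound 2 is `COc1cccc(NC(=O)c2nnn(Cc3ccc(C#N)cc3)c2N)c1`. In this assay compound 2 gives > 50100 nM, again a limit of the assay.
Compound 3 is `COc1cccc(NC(=O)c2nnn(Cc3ccc(OC(F)(F)F)cc3)c2N)c1`. In this assay compound 3 gives > 50100 nM, also a limit of the assay.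

All three measured compounds share one core and differ only in the group on the aromatic carbon of the outer ring. Compound 3 therefore stands where the other two stand: at the limit, with no number that would set it apart, as the limit of > 50100 nM in this assay, at which 3 of the 3 values shown sit, records.

The step to compound 4, `COc1cccc(NC(=O)c2nnn(Cc3ccc(C4CC4)cc3)c2N)c1`, is cyclopropyl in place of trifluoromethoxy on an aromatic carbon.

Among the measured compounds shown here, three measured steps touch this position. a step that the two limits leave unreadable from compound 1 to compound 2, a step that the two limits leave unreadable from compound 1 to compound 3 and a step that the two limits leave unreadable from compound 2 to compound 3 all remain unreadable, since each pair sits on the same limit. For the measured compounds named here, they show only that swapping the group at this carbon has so far not brought any compound into the measurable range of this assay.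

On that basis compound 4 is expected to behave like its neighbours: the estimated step that the limit leaves unreadable from compound 3 to compound 4 is none that can be read, and compound 4 is expected to give about 60000 nM in this assay, within 20000 nM to 150000 nM, most likely reported as a limit once more.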

Compound 4, half-maximal effective concentration in the Vero assay: > 50100 nM
Compound 4: no number, only a limit; the forecaster's own chance of this, stated with the estimate: 85%; the middle value does not contradict the limit.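

In the Vero assay compound 4 gives > 50100 nM as a limit of the assay and not a number. Among the compounds shown here, compounds 1, 2 and 3 sit at the same limit, so no new step from any of them to compound 4 can be read. The compounds shown leave open how much of any of them is needed for the effect in the Vero assay and whether any group on this aromatic carbon would give a measurable value. In a physicochemical assay for lipophilicity, read by HPLC, measured as chromatographic lipophilicity, at pH 7.4 (on this read-out lower numbers stand for lower lipophilicity and higher numbers for higher lipophilicity), compound 3 gives 3.6 as a measured number. In the physicochemical assay compound 4 gives 3.2 as a measured number. In the physicochemical assay cyclopropyl in place of trifluoromethoxy is a number 0.40 log units lower from compound 3 to compound 4 (beyond the scatter) on this read-out.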